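The source may report more compounds than this note shows. Statements on the series, on what has been measured and on what is new or still open speak of the compounds shown alone.

Compounds measured in an ADME assay on MDCK cells (Canis lupus familiaris) for cytotoxicity, read by microscopy, with a stated time of 48 h; on this read-out higher numbers stand for lower toxicity in this test and lower numbers for higher toxicity in this test:

compound 1, `C[C@H]1[C@H](NCc2ccc(C(C)(C)C)s2)C[C@H]2C[C@@H]1C2(C)C`, 780 nM
compound 2, `CCc1ccsc1CN[C@@H]1C[C@H]2C[C@@H]([C@H]1C)C2(C)C`, 25000 nM
compound 3, `C[C@H]1[C@H](NCc2sccc2C2CCCC2)C[C@H]2C[C@@H]1C2(C)C`, 12500 nM

Compound 1 stands apart on these numbers: it gives the lowest value of the three, a step beyond the scatter from both compound 2 and compound 3, and so it is the most cytotoxic of the measured set in this assay. The unmeasured compound 4, `C[C@H]1[C@H](NCc2ccc(Cl)s2)C[C@H]2C[C@@H]1C2(C)C`, differs from compound 1 in one place: chloro in place of tert-butyl on an aromatic carbon.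

Within the data shown here, only one measured step is available, a 2.0-fold lower number from compound 2 to compound 3 (0.30 log units; within the scatter), and it concerns a different group at a different position of the ring, so it speaks to the present change only loosely. It shows that swapping one group for another on the same aromatic ring can leave the number within the scatter. Among the measured compounds shown here, no measured pair isolates tert-butyl against chloro. Since both compound 2 and compound 3, which carry other groups on that ring, give far higher numbers than compound 1, compound 4 is expected to move toward them, though the size is uncertain. Compound 4 is therefore estimated at 5000 nM, with a range from 1200 nM to 25000 nM, a step of a 6.4-fold higher number from compound 1 to compound 4 (0.81 log units; beyond the scatter) being expected.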

Compound 4, minimum cytotoxic concentration: 25000 nM
For compound 4 the middle estimate is 5.0-fold (0.70 log units) below the measured one; the measured number falls inside the stated range.
By their numbers in this assay, from the lowest: compound 1; then compounds 3, 2 and 4 (each within the scatter of the next).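

In this assay, the position next to the ring sulfur proves sensitive to the group it carries: chloro in place of tert-butyl gives a 32-fold higher number from compound 1 to compound 4 (1.51 log units; beyond the scatter), a large step beyond the scatter. Compound 1 and compound 4 match everywhere else, so the low number of compound 1 goes with its tert-butyl group and not with the shared core. Nothing measured here bears on why this step is so large.

The compounds shown hold only these two groups at this position, so they leave open whether the number climbs gradually or sharply on going from tert-butyl to chloro. An isopropyl or a bromo at this position would help to settle that question, as would a methoxy.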